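This account rests on a few compounds, and the source may have more. Where it says the series, first, only, none or still open, it means among the compounds named here.

Compound 1 `COc1cccc(OC)c1C(=O)Nc1c[nH]nc1C(=O)NCC1CCCCC1`: > 50000 nM
Compound 2 `CCCCCNC(=O)c1n[nH]cc1NC(=O)c1c(OC)cccc1OC`: > 50000 nM
Compound 3 `COc1cccc(OC)c1C(=O)Nc1c[nH]nc1C(=O)Nc1ccccc1`: > 50000 nM

In an ADME assay on MRC5 cells (Homo sapiens) for inhibition, with a stated time of 72 h (a higher number here means that more compound is needed for the effect, a lower number that less compound is needed), compound 3 gives > 50000 nM, which is a limit and not a number. It has no readable position among the three measured compounds, as the evidence shows: the limit of > 50000 nM in this assay, at which 3 of the 3 values shown sit.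

Compound 4 `COc1cccc(OC)c1C(=O)Nc1c[nH]nc1C(=O)NC1CCCCC1` carries cyclohexyl in place of phenyl on an amide-type nitrogen.

Two measured steps change the group on that same nitrogen: a step that the two limits leave unreadable from compound 1 to compound 3 and a step that the two limits leave unreadable from compound 2 to compound 3. The first puts phenyl in place of cyclohexylmethyl and the second puts phenyl in place of pentyl. Neither has a size that can be read, and the same holds for a step that the two limits leave unreadable from compound 1 to compound 2. They offer no size or direction to carry over, so no step beyond the scatter is expected in this assay.

The estimated a number no higher from compound 3 to compound 4 (the limit leaves the size open) therefore has no firm direction. Compound 4 is most likely to be reported as a limit too.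

For compound 4 the expected value is 50000 nM, with an estimated range from 25000 nM to 100000 nM.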

Compound 4, half-maximal effective concentration: 35000 nM
For compound 4 the middle estimate is 1.4-fold (0.15 log units) above the measured one, and the stated range covers the measured number.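

In this assay compound 4 is the only one of the four compounds with a number rather than a limit: the limit of > 50000 nM in this assay, at which 3 of the 4 values shown sit.

Cyclohexyl in place of phenyl gives an at least 1.4-fold lower number from compound 3 to compound 4 (0.15 log units; that floor lies within the scatter), cyclohexyl in place of pentyl gives an at least 1.4-fold lower number from compound 2 to compound 4 (0.15 log units; that floor lies within the scatter), and cyclohexyl in place of cyclohexylmethyl gives an at least 1.4-fold lower number from compound 1 to compound 4 (0.15 log units; that floor lies within the scatter). Each of these steps now has a direction, but only a floor for its size, and that floor lies within the scatter; the steps among compound 1, compound 2 and compound 3 cannot be read.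

The compounds shown leave open whether the full size of any of these steps lies beyond the scatter. They also leave open how this assay would read with cyclopentyl on the amide-type nitrogen, or with an amine or a carboxylic acid on the cyclohexyl group.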